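A few compounds are considered here, and "the series" means these few. Any claim that something is new, unique, unknown or untested is made for them only; others in the source may bear on it.

Measured so far in a physicochemical assay for solubility, measured as kinetic solubility, with a stated time of 1 h, at pH 7.4; on this read-out lower numbers stand for lower solubility and higher numbers for higher solubility:
- compound 1 `N#CCCC(=O)NC1=NN(c2ccc(Cl)c(Cl)c2)CC1`: 39000 nM
- compound 2 `O=C(NC1=NN(c2ccc(Cl)c(Cl)c2)CC1)c1cccnn1`: 67000 nM

In this assay compound 2, at 67000 nM, stands within the scatter of compound 1, so the two values cannot be ranked. The next compound is compound 3 `O=C(NC1=NN(c2ccc(Cl)c(Cl)c2)CC1)c1ccncn1`, which has pyrimidin-4-yl in place of pyridazin-3-yl on a carbonyl carbon.

Among the compounds with values here, only one measured step bears on this change: a 1.7-fold higher number from compound 1 to compound 2 (0.24 log units; within the scatter). That step put pyridazin-3-yl in place of 2-cyanoethyl on the same carbonyl carbon, and it lies within the scatter. Within the data shown here, no measured pair exchanges one of these rings for the other, so the evidence is indirect and rests on two compounds. Among the measured compounds shown here, with the only step at this position inside the scatter, no clear shift is expected from the ring exchange, in either direction.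

The estimated step is a 1.2-fold lower number from compound 2 to compound 3 (0.09 log units; within the scatter), which is not expected to exceed the scatter. Compound 3 is expected at 55000 nM, with an estimated range of 25000 nM to 110000 nM.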

Compound 3, solubility: 13000 nM
For compound 3 the middle estimate is 4.2-fold (0.63 log units) above the measured one; the measured number lies below the stated range.
By their numbers in this assay, from the lowest: compound 3; then compounds 1 and 2 (each within the scatter of the next).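

In this assay, within the data shown here, the exchange of pyridazin-3-yl for pyrimidin-4-yl on the carbonyl carbon gives the first step at this position that passes the scatter, with a 5.2-fold lower number from compound 2 to compound 3 (0.71 log units; beyond the scatter) between two groups that have the same heavy-atom count, ring size and hydrogen-bond counts; what separates them is how the same atoms are joined. The 2-cyanoethyl comparison points the same way, with a 3.0-fold lower number from compound 1 to compound 3 (0.48 log units; beyond the scatter) where the step to the other ring, a 1.7-fold higher number from compound 1 to compound 2 (0.24 log units; within the scatter), stayed within the scatter, so at this position the two rings cannot be treated as interchangeable. The compounds shown offer no measurement that explains the difference between the two rings.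

Still open, as far as these compounds go, is how other groups on this carbonyl carbon would fall relative to these two rings, for example pyrazin-2-yl, pyrimidin-2-yl or a plain phenyl ring. Also open, from the compounds shown here alone, is whether the gap between pyridazin-3-yl and pyrimidin-4-yl persists when the groups on the rest of the core change, such as an amine in place of one of the ring chlorines.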